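The source may report more compounds than this note shows. Statements on the series, on what has been measured and on what is new or still open speak of the compounds shown alone.

Measured so far in a functional assay on K562 cells (Homo sapiens) for cytotoxicity, read by MTT assay, with a stated time of 48 h; on this read-out higher numbers stand for weaker inhibition and lower numbers for stronger inhibition:
- compound 1 `Cc1ccccc1CN1CCN(C(=O)CN[C@H]2CCN(S(=O)(=O)Cc3ccccc3)C2)CC1` gives 10200 nM
- compound 2 `Cc1cccc(CN2CCN(C(=O)CN[C@H]3CCN(S(=O)(=O)Cc4ccccc4)C3)CC2)c1` gives 11300 nM
- compound 3 `O=C(CN[C@H]1CCN(S(=O)(=O)Cc2ccccc2)C1)N1CCN(Cc2ccc(Cl)cc2)CC1` gives 9200 nM

Compound 3 stands level with the other two compounds, and no order can be read among the three. The steps that reach it are a 1.1-fold lower number from compound 1 to compound 3 (0.04 log units; within the scatter) and a 1.2-fold lower number from compound 2 to compound 3 (0.09 log units; within the scatter).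

Compound 4 `O=C(CN[C@H]1CCN(S(=O)(=O)Cc2ccccc2)C1)N1CCN(Cc2cccc(C(F)(F)F)c2)CC1` is not yet measured. It differs from compound 3 in one place, on a saturated chain carbon bound to an amine nitrogen in a ring: 3-(trifluoromethyl)phenyl in place of 4-chlorophenyl on a saturated chain carbon bound to an amine nitrogen in a ring.

All three measured steps bear on this change, since each swaps one substituted phenyl for another at that place. The third is a 1.1-fold higher number from compound 1 to compound 2 (0.04 log units; within the scatter), and none of the three leaves the scatter. For the measured compounds named here, no measured compound carries a trifluoromethyl group, so this expectation is an extrapolation and the range is kept wide.

No step beyond the scatter is expected in this assay, and the estimated step is a 1.0-fold higher number from compound 3 to compound 4 (0.01 log units; within the scatter).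

For compound 4 the estimate is 9500 nM, with an expected range of 5000 nM to 18000 nM.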

Compound 4, half-maximal inhibitory concentration: 3600 nM
The estimate for compound 4 lay 2.6-fold (0.42 log units) above the measured number, and the stated range ends above it.
By their numbers in this assay, from the lowest: compound 4; then compounds 3, 1 and 2 (each within the scatter of the next).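

In this assay, this place, a saturated chain carbon bound to an amine nitrogen in a ring, now shows steps beyond the scatter (a 2.6-fold lower number from compound 3 to compound 4 (0.41 log units; beyond the scatter)) and (a 2.8-fold lower number from compound 1 to compound 4 (0.45 log units; beyond the scatter)), whereas the swaps among 2-methylphenyl, 3-methylphenyl and 4-chlorophenyl all stayed within it. The change of trifluoromethyl for methyl on an aromatic carbon alone also gives such a step (a 3.1-fold lower number from compound 2 to compound 4 (0.50 log units; beyond the scatter)), so among these four compounds the separation goes with the trifluoromethyl group. No measurement bearing on the reason for this result is available.

The compounds shown leave open whether the lower number is particular to trifluoromethyl or also appears with a nitrile or a methoxy group on the phenyl. Whether the step holds on a different core also remains unanswered, since all four compounds share one core.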